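Benzoyl to butanoyl on a tetrahydroquinoline amide core

A few compounds are considered here, and "the series" means these few. Any claim that something is new, unique, unknown or untested is made for them only; others in the source may bear on it.

Compound 1 `O=C(Nc1ccccc1C(F)(F)F)C1CCc2ccccc2N1C(=O)c1ccccc1` is a tetrahydroquinoline carboxamide that carries a benzoyl group on the ring nitrogen. In a functional assay on NCI-H23 cells (Homo sapiens) for cytotoxicity, read by sulforhodamine B assay, with a stated time of 72 h (a higher number here means a weaker inhibitor of growth, a lower number a stronger inhibitor of growth), compound 1 gives 6340 nM, the highest of the two numbers obtained so far. Its closest neighbour is compound 3 `O=C(Nc1ccccc1O)C1CCc2ccccc2N1C(=O)c1ccccc1`, which differs only in the aniline substituent; in this assay compound 3 gives 3490 nM, and the step of a 1.8-fold lower number from compound 1 to compound 3 (0.26 log units; within the scatter) does not leave the scatter. Compound 2 `O=C(Nc1ccccc1C(F)(F)F)c1ccc2ccccc2n1`, an aromatic analogue of the shared core, reaches only a limit of this assay rather than a number, namely > 90000 nM (the limit of > 90000 nM in this assay, at which 1 of the 3 values shown sits).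

Compound 4 `CCCC(=O)N1c2ccccc2CCC1C(=O)Nc1ccccc1C(F)(F)F` keeps the trifluoromethyl aniline of compound 1 and changes the acyl group: propyl in place of phenyl on a carbonyl carbon. Going by the values given here, no measured step touches this part of the molecule, so the single step from compound 1 to compound 3 offers no direct guidance, and the change from an aromatic to a short aliphatic acyl group leaves the expectation open. The author therefore expects a modest rise in the number, a 1.7-fold higher number from compound 1 to compound 4 (0.24 log units; within the scatter), with wide uncertainty. For compound 4 the estimate in this assay is 11000 nM, spanning from 4000 nM to 35000 nM.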

Compound 4, concentration for 50% growth inhibition: > 70000 nM
Compound 4 gave a limit, no number; the forecaster's own chance of this, stated with the estimate: 10%; at least 6.3-fold (0.80 log units) between middle value and limit.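

Going by these compounds alone, the carbonyl position proves far more sensitive in this assay than the one earlier step suggested: a 1.8-fold lower number from compound 1 to compound 3 (0.26 log units; within the scatter), with hydroxy in place of trifluoromethyl on an aromatic carbon, whereas the new step, an at least 11-fold higher number from compound 1 to compound 4 (1.04 log units; beyond the scatter), comes from propyl in place of phenyl on a carbonyl carbon. Compound 4 gives a limit and no number: the limit of > 70000 nM in this assay, at which 1 of the 4 values shown sits. Keeping the rest of compound 1 fixed, this one change therefore takes the series from a measurable number to a limit, so the step shows a minimum and not its full size.

From the compounds shown here alone, it remains open whether the phenyl ring itself matters or merely the size of the group that enters, and a cyclohexyl group or a longer chain on the same carbonyl carbon would be needed to separate those two readings. It is also open whether hydroxy in place of trifluoromethyl would change the outcome when propyl stands on the carbonyl carbon, as the compounds shown do not carry both groups together.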